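Chloro for Trifluoromethyl, Tried a Second Time

This account rests on a few compounds, and the source may have more. Where it says the series, first, only, none or still open, it means among the compounds named here.

Compound 1 `O=C(Nc1cccc(-n2cc(-c3ccncc3)c(-c3cc(O)cc(Cl)c3)n2)c1)Nc1ccc(Cl)c(C(F)(F)F)c1` was tested in a functional assay on MDA-MB-468 cells (Homo sapiens) for inhibition, read by sulforhodamine B assay, with a stated time of 48 h, tested at 0.1 uM (a higher number here means a weaker effect of the compound at the concentration tested, a lower number a stronger effect), where compound 1 gives 94%. Compound 2 `O=C(Nc1cccc(-n2cc(-c3ccncc3)c(-c3cc(O)cc(Cl)c3)n2)c1)Nc1ccc(Cl)c(Cl)c1` carries chloro in place of trifluoromethyl on an aromatic carbon and, in this assay, compound 2 gives 85%. The change gives a number 9 percentage points lower from compound 1 to compound 2 (within the scatter).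

Compound 3 `COc1cc(Cl)cc(-c2nn(-c3cccc(NC(=O)Nc4ccc(Cl)c(C(F)(F)F)c4)c3)cc2-c2ccncc2)c1` differs from compound 1 in its core by methyl in place of hydrogen on an oxygen on an aromatic ring. In this assay compound 3 gives 91%, which amounts to a number 3 percentage points lower from compound 1 to compound 3 (within the scatter). The three measured values therefore sit close together, and none of the three compounds can be set apart from the others on this evidence.

Compound 4 `COc1cc(Cl)cc(-c2nn(-c3cccc(NC(=O)Nc4ccc(Cl)c(Cl)c4)c3)cc2-c2ccncc2)c1` has not yet been measured in this assay. It stands to compound 3 as compound 2 stands to compound 1: the difference is chloro in place of trifluoromethyl on an aromatic carbon, the same change seen once before, on the same kind of position in the same surroundings. Because a number 9 percentage points lower from compound 1 to compound 2 (within the scatter), the step expected from the same change on the core of compound 3 is estimated at a number 7 percentage points lower from compound 3 to compound 4 (within the scatter). On that basis compound 4 is expected to give 84% in this assay. The expected range for compound 4 runs from 70% to 96%, since a single earlier step within the scatter gives only weak guidance.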

Compound 4, a percentage reported as activity, at one concentration (the size of the read-out at that concentration, not a potency): 97%
Beside the measured number, compound 4's estimate is 13 percentage points below it; the measured number lies above the stated range.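

In this assay, chloro in place of trifluoromethyl on the core of compound 3 gives a number 6 percentage points higher from compound 3 to compound 4 (within the scatter), so the step seen on the core of compound 1 does not simply carry over, and the two steps differ: the same change on two cores in this assay, a number 9 percentage points lower (within the scatter) from compound 1 to compound 2 and a number 6 percentage points higher (within the scatter) from compound 3 to compound 4, 15 percentage points apart, beyond the scatter of two such steps

The methyl on the oxygen tells the same story from the other side, since it gives a number 12 percentage points higher from compound 2 to compound 4 (beyond the scatter), a modest step, and this too differs from its earlier counterpart: the same change on two cores in this assay, a number 3 percentage points lower (within the scatter) from compound 1 to compound 3 and a number 12 percentage points higher (beyond the scatter) from compound 2 to compound 4, 15 percentage points apart, beyond the scatter of two such steps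

Within these compounds, then, the effect of either change depends on the core that carries it, so a step read on one core is a poor guide to the next; this does not show why the two changes fail to add up, nor does it give a rule for the series, as each comparison rests on just two pairs at a single concentration.

The compounds shown leave open whether the same dependence on the core would appear with another group in place of trifluoromethyl, such as a nitrile or a bromo group. They also leave open how the core would respond if the hydroxyl gave way to an amine, or if the methyl on the oxygen gave way to a longer chain.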